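The compounds below may be only part of what the source reports. "The series", "measured", "known", "first", "only" and "open" are said of these compounds alone.

Measured so far:
Compound 1, `CCCNS(=O)(=O)c1ccc(Nc2ncc3c(n2)N(C2CCCC2)[C@H](CC)C(=O)N3C)cc1`, gives 344 nM in a functional assay on MCF7 cells (Homo sapiens) for antiproliferative activity, read by CCK-8 assay, with a stated time of 72 h; a lower number here means a stronger inhibitor of growth, a higher number a weaker inhibitor of growth.
Compound 2, `CC[C@@H]1C(=O)N(C)c2cnc(-n3ccc4cc(C(=O)NCC(C)C)ccc43)nc2N1C1CCCC1`, gives 953 nM in this assay.

Within the data shown here, of these two numbers, compound 2 holds the higher one, and its only neighbour, compound 1, sits enough lower that the gap lies beyond the usual scatter; compound 2 is thus the weaker growth inhibitor of the pair. Compound 3, `CC[C@@H]1C(=O)N(C)c2cnc(-n3ccc4cc(C(=O)NC)ccc43)nc2N1C1CCCC1`, has not yet been measured. It differs from compound 2 in one place: hydrogen in place of isopropyl on a saturated chain carbon bound to an amide-type nitrogen. Among the measured compounds shown here, no measured pair here shows a change of this kind, so nothing among the numbers so far sets the size of such a step. The expected step in this assay is a 1.3-fold higher number from compound 2 to compound 3 (0.10 log units; within the scatter), a small one, if anything toward a weaker inhibitor, and not clearly beyond the scatter. Compound 3 is estimated at 1200 nM, with a range from 400 nM to 3600 nM.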

Compound 3, concentration for 50% growth inhibition: 1000 nM
The estimate for compound 3 lay 1.2-fold (0.08 log units) above the measured number; measured number inside the range.
By their numbers in this assay, from the lowest: compound 1; then compounds 2 and 3 (each within the scatter of the next).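

Within this assay, the first pair differing in one place shows a 1.0-fold higher number from compound 2 to compound 3 (0.02 log units; within the scatter) when isobutylcarbamoyl is shortened to methylcarbamoyl. Removing the isopropyl, with its three carbons, therefore leaves no change beyond the scatter at this position, so the full isobutyl chain is not needed to keep this level of growth inhibition in these cells. The data offer no measured explanation for this flat result.

From the compounds shown here alone, whether a longer chain, or a chain ending in an amine or a carboxylic acid, would keep the same reading remains open. Compound 1 differs from the other two compounds in more than one place, so the compounds shown cannot say which part of its structure accounts for its separate number.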